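Adding One Methyl to Compound 1

This account rests on a few compounds, and the source may have more. Where it says the series, first, only, none or still open, it means among the compounds named here.

Measured in a functional assay on HepG2 cells (Homo sapiens) for cytotoxicity, read by ELISA, with stated times of 2 h and 48 h; on this read-out lower numbers stand for stronger inhibition and higher numbers for weaker inhibition:
compound 1 `C/C(=N\NC(=O)c1sc(N)c(C#N)c1N)c1ccc(NS(=O)(=O)c2ccccc2)cc1`: 18300 nM
compound 2 `C/C(=N/NC(=O)C(C#N)C(=S)S)c1ccc(NS(=O)(=O)c2ccc(C)cc2)cc1`: 5000 nM

Of these two, compound 1 carries the higher number, which means weaker inhibition in this assay, and its gap to compound 2 lies beyond the usual scatter. Compound 3 `C/C(=N\NC(=O)c1sc(N)c(C#N)c1N)c1ccc(NS(=O)(=O)c2ccc(C)cc2)cc1` has not been measured yet. It is compound 1 with methyl in place of hydrogen on an aromatic carbon, para to a large group (methyl in place of hydrogen on an aromatic carbon), turning phenylsulfonyl into (4-methylphenyl)sulfonyl. Compound 2 also carries (4-methylphenyl)sulfonyl, but the rest of its structure differs from compound 1. Among the measured compounds shown here, the expectation therefore starts from compound 1 at 18300 nM, and with no measured pair showing this methyl alone, the step expected in this assay is small, within the scatter, leaning slightly towards a lower number. The estimate amounts to a 1.3-fold lower number from compound 1 to compound 3 (0.12 log units; within the scatter). For compound 3 the expected value is 14000 nM, with an estimated range of 6000 nM to 32000 nM.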

Compound 3, half-maximal inhibitory concentration: 5800 nM
Beside the measured number, compound 3's estimate is 2.4-fold (0.38 log units) above it; the measured number lies below the stated range.
By their numbers in this assay, from the lowest: compounds 2 and 3 (each within the scatter of the next); then compound 1.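

Turning phenylsulfonyl into (4-methylphenyl)sulfonyl is the first change here that can be read on its own, and in this assay it gives a 3.2-fold lower number from compound 1 to compound 3 (0.50 log units; beyond the scatter). This shows that the aromatic carbon para to a large group is a place where a small edit counts: one added carbon, with no hydrogen-bond donors or acceptors and no net charge, is enough to shift the result towards stronger inhibition. No measurement available here explains why the number falls.

From the compounds shown here alone, whether an ethyl group, a chlorine atom or a methoxy group at this same place would move the number further, or reverse the step, remains open. Going by these compounds, it is also open whether the methyl has a similar effect on the different structure of compound 2.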